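The source may hold more compounds than are shown below. What is called first, only, known or untested is meant among the compounds shown, and "the series" means these compounds.

Measured in a functional assay on P388 cells (Mus musculus) for antiproliferative activity; a higher number here means a weaker inhibitor, a lower number a stronger inhibitor:
Compound 1 `N#Cc1c[nH]c2c(NS(=O)(=O)c3ccc(N)cc3)cccc12`: 0.72 ug/mL
Compound 2 `N#Cc1ccc(S(=O)(=O)Nc2cccc3c(Cl)c[nH]c23)cc1`: 1.4 ug/mL

In this assay compound 2 gives 1.4 ug/mL and compound 1 gives 0.72 ug/mL. These two values lie within the usual scatter of each other, so the data do not rank the two compounds.

Compound 3 `Nc1ccc(S(=O)(=O)Nc2cccc3c(Cl)c[nH]c23)cc1` keeps the rest of compound 2 and has amino in place of cyano on an aromatic carbon, para to a large group (amino in place of cyano on an aromatic carbon). Among the measured compounds shown here, no measured pair shows this change alone, so the data give no direct size for it in this assay. Compound 1 also carries an amino group and gives 0.72 ug/mL, which offers only indirect support for a similar value. The expected step of a 1.8-fold lower number from compound 2 to compound 3 (0.24 log units; within the scatter) therefore stays within the scatter, with no firm direction. Compound 3 is estimated at 0.8 ug/mL, with an expected range of 0.25 ug/mL to 2.5 ug/mL.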

Compound 3, half-maximal inhibitory concentration: 0.81 ug/mL
For compound 3 the middle estimate is 1.0-fold (0.01 log units) below the measured one; the range from low to high includes it.
By their numbers in this assay, from the lowest: compounds 1, 3 and 2 (each within the scatter of the next).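

In this assay, among the compounds shown here, amino in place of cyano on an aromatic carbon, para to a large group, now has a direct measure: a 1.7-fold lower number from compound 2 to compound 3 (0.24 log units; within the scatter) is the size of this step, the first pair to show this change alone. The new compound also gives a second pair, in which cyano gives way to chloro at a different place on the shared core: a 1.1-fold higher number from compound 1 to compound 3 (0.05 log units; within the scatter) is that step, so cyano is exchanged in both pairs and neither step rises above the scatter. No measurement shown here offers an explanation for either step.

As far as these compounds go, only cyano and amino have been seen at the carbon para to a large group, so it remains open whether a carboxylic acid or a longer chain there would separate from these values. The same question stands for bromo or methoxy at the carbon carrying chloro in compound 3.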